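Swapping Methylsulfanyl for Trifluoromethoxy on the Amide Aryl

The compounds below may be only part of what the source reports. "The series", "measured", "known", "first", "only" and "open" are said of these compounds alone.

Compound 1 `CSc1cccc(NC(=O)CN2CCC(c3cccc[n+]3[O-])CC2)c1` carries a methylsulfanyl group on the aromatic ring bound to the amide-type nitrogen. In a functional assay on HEK293 cells for agonist activity at D(4) dopamine receptor (Homo sapiens), read by FLIPR (on this read-out higher numbers stand for an effect only at larger amounts of compound and lower numbers for an effect already at smaller amounts), compound 1 gives 100 nM, the second highest of the three numbers measured. Compound 2 `Cc1cc(F)ccc1NC(=O)CN1CCC(c2cccc[n+]2[O-])CC1` gives 60 nM, and compound 3 `Cc1cccc(C)c1NC(=O)CN1CCC(c2cccc[n+]2[O-])CC1` gives 346 nM. The step of a 1.7-fold lower number from compound 1 to compound 2 (0.22 log units; within the scatter) lies within the scatter, whereas a 3.5-fold higher number from compound 1 to compound 3 (0.54 log units; beyond the scatter) and a 5.8-fold higher number from compound 2 to compound 3 (0.76 log units; beyond the scatter) are modest shifts.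

Compound 4 `O=C(CN1CCC(c2cccc[n+]2[O-])CC1)Nc1cccc(OC(F)(F)F)c1` differs from compound 1 in one place: trifluoromethoxy in place of methylsulfanyl on an aromatic carbon. Among the measured compounds shown here, no measured step alters only this group; each of the three steps above exchanges the whole aromatic group on the amide-type nitrogen, and those exchanges span from within the scatter to a modest shift. The change to compound 4 keeps the same aromatic group and alters a single substituent on it. Compound 4 is therefore expected to land close to compound 1, with a step of a 1.2-fold higher number from compound 1 to compound 4 (0.08 log units; within the scatter) that is expected to stay within the scatter. The estimate for compound 4 in this assay is 120 nM, with a range from 40 nM to 360 nM.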

Compound 4, half-maximal effective concentration: 135 nM
Compound 4: middle estimate off by 1.1-fold (0.05 log units), on the low side; measured number inside the range.
By their numbers in this assay, from the lowest: compounds 2, 1 and 4 (each within the scatter of the next, the first and the last beyond it); then compound 3.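

Among the compounds shown here, compound 4 is the first case here in which the aromatic group on the amide-type nitrogen stays the same and only one substituent on it changes. In this assay, replacing methylsulfanyl with trifluoromethoxy on this aromatic carbon, meta to a large group, gives a 1.4-fold higher number from compound 1 to compound 4 (0.13 log units; within the scatter), so this exchange of a group of 2 heavy atoms for one of 5 leaves no difference that can be told from the scatter. No available measurement bears on the reason for this result.

From the compounds shown here alone, it remains open whether an amine, a carboxylic acid or a longer chain such as n-butyl would be tolerated on the same aromatic carbon. The compounds shown also leave open how trifluoromethoxy would read on a different carbon of this ring.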